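The compounds below may be only part of what the source reports. "The series", "measured", "known", "first", "only" and "open" are said of these compounds alone.

In an assay on HEK293 cells for displacement of a labelled ligand from 5-hydroxytryptamine receptor 6 (Homo sapiens) (on this read-out higher numbers stand for weaker inhibition and lower numbers for stronger inhibition), compound 2 `O=C1c2ccccc2S(=O)(=O)N1CCCCCN1CCN(c2ccccc2)CC1` gives 1840 nM, the higher of the two numbers recorded so far, while compound 1 `O=C1c2ccccc2S(=O)(=O)N1CCCCCCN1CCN(c2cccc(Cl)c2Cl)CC1` gives 72 nM in this assay. Compound 3 `O=C1c2ccccc2S(=O)(=O)N1CCCCCN1CCN(c2cccc(C(F)(F)F)c2)CC1` differs from compound 2 in a single place: trifluoromethyl in place of hydrogen on an aromatic carbon, with the new group sitting on an aromatic carbon of a six-membered aromatic ring of carbon only. Among the compounds with values here, no measured pair isolates this exact change, so its size can only be expected, not read off. Compound 2 gives 1840 nM in this assay. The change is expected to lower the number, by a 6.1-fold lower number from compound 2 to compound 3 (0.79 log units; beyond the scatter), beyond the usual scatter. Compound 3 is therefore estimated at 300 nM, between 60 nM and 1500 nM.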

Compound 3, inhibition constant: 1350 nM
Beside the measured number, compound 3's estimate is 4.5-fold (0.65 log units) below it; the measured number falls inside the stated range.
By their numbers in this assay, from the lowest: compound 1; then compounds 3 and 2 (each within the scatter of the next).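

Replacing hydrogen with trifluoromethyl, which turns phenyl into 3-(trifluoromethyl)phenyl, gives a 1.4-fold lower number from compound 2 to compound 3 (0.13 log units; within the scatter) in this assay. Within the data shown here, this is the first single-change pair, and it shows that adding this group at this position leaves the number unchanged within the usual scatter. On these data alone, it remains open whether a methoxy group or an amine on the same aromatic carbon would shift the number, and whether trifluoromethyl would have the same small effect on a compound with a longer chain. Nothing measured here offers an explanation for this result.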